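Amide side-chain swap on the shared core

A few compounds are considered here, and "the series" means these few. Any claim that something is new, unique, unknown or untested is made for them only; others in the source may bear on it.

Going by the values given here, compound 1 `CS(=O)(=O)Oc1c(C(=O)NCc2ccc(F)cc2)nc(Br)c2cccnc12` gives in a functional assay on MDA-MB-435 cells (Homo sapiens) for cytotoxicity, read by MTT assay, with a stated time of 72 h (on this read-out higher numbers stand for weaker inhibition and lower numbers for stronger inhibition), the value > 20000 nM, which is a limit of the assay and not a number; it is the one value sitting at the limit of > 20000 nM in this assay, at which 1 of the 2 values shown sits. Among the compounds with values here, compound 2 `N[C@H]1CC[C@H](Nc2c(C(=O)NCc3ccccn3)nc(Br)c3cccnc23)CC1` is the only compound with a number in this assay, at 4000 nM. Compound 3 `CN(C)c1ccc(CNC(=O)c2nc(Br)c3cccnc3c2N[C@H]2CC[C@H](N)CC2)cc1` differs from compound 2 in one place: 4-(dimethylamino)phenyl in place of pyridin-2-yl on a saturated chain carbon bound to an amide-type nitrogen. Within the data shown here, no step between two measured compounds exists to set a scale for this change, so a step no larger than the usual scatter, in no settled direction, is expected, namely a 1.3-fold lower number from compound 2 to compound 3 (0.12 log units; within the scatter). Compound 3 is therefore estimated at 3000 nM, within 1000 nM to 10000 nM.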

Compound 3, half-maximal inhibitory concentration: 4000 nM
Beside the measured number, compound 3's estimate is 1.3-fold (0.12 log units) below it; measured number inside the range.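

In this assay, the first step read at this position gives no change at the digits printed from compound 2 to compound 3 (within the scatter). On a saturated chain carbon bound to an amide-type nitrogen, 4-(dimethylamino)phenyl can therefore take the place of pyridin-2-yl with the number holding, so the ring nitrogen of pyridin-2-yl is not needed for this value. Nothing shown here gives a cause for this flat step.

As far as these compounds go, whether a carboxylic acid on the ring or a longer chain would shift the value remains open. A single step also leaves open whether this position ever moves the number.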